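Amide aryl variation: 4-methoxyphenyl to quinolin-2-yl

The source may hold more compounds than are shown below. What is called first, only, known or untested is meant among the compounds shown, and "the series" means these compounds.

Measured compounds:
compound 1 `CCN1CCN(c2cc(C)c3cc(NC(=O)c4ccccc4F)ccc3n2)CC1`: 32600 nM
compound 2 `CCc1ccccc1C(=O)Nc1ccc2nc(N3CCN(CC)CC3)cc(C)c2c1`: 15800 nM
compound 3 `CCN1CCN(c2cc(C)c3cc(NC(=O)c4ccc(OC)cc4)ccc3n2)CC1`: 7690 nM

All three values come from a functional assay on MCF7 cells (Homo sapiens) for antiproliferative activity, read by MTT assay, with a stated time of 72 h; on this read-out higher numbers stand for weaker inhibition and lower numbers for stronger inhibition. Compound 3 has the lowest number of the three; the steps of a 4.2-fold lower number from compound 1 to compound 3 (0.63 log units; beyond the scatter) and a 2.1-fold lower number from compound 2 to compound 3 (0.31 log units; beyond the scatter) both run the same way, and a 2.1-fold lower number from compound 1 to compound 2 (0.31 log units; beyond the scatter) is of the same order. Every measured step is a swap of the aryl group on the carbonyl carbon, and each was modest.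

Compound 4 `CCN1CCN(c2cc(C)c3cc(NC(=O)c4ccc5ccccc5n4)ccc3n2)CC1` continues this pattern: quinolin-2-yl in place of 4-methoxyphenyl on a carbonyl carbon. Within the data shown here, no measured step brings in a second ring or a ring with a hetero atom, so only the size of the earlier aryl swaps can guide the expectation; a modest step in either direction is plausible. Compound 4 is expected to give 5000 nM, in the range 1500 nM to 16000 nM. The expected step of a 1.5-fold lower number from compound 3 to compound 4 (0.19 log units; within the scatter) is small.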

Compound 4, half-maximal inhibitory concentration: 7060 nM
Beside the measured number, compound 4's estimate is 1.4-fold (0.15 log units) below it; low and high end bracket the measured number.
By their numbers in this assay, from the lowest: compounds 4 and 3 (each within the scatter of the next); then compound 2; then compound 1.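

In this assay, quinolin-2-yl on the carbonyl carbon brings in a second ring and a ring nitrogen, and the step is small: a 1.1-fold lower number from compound 3 to compound 4 (0.04 log units; within the scatter). Against the other two aryl groups, the steps are a 2.2-fold lower number from compound 2 to compound 4 (0.35 log units; beyond the scatter) and a 4.6-fold lower number from compound 1 to compound 4 (0.66 log units; beyond the scatter), so this position tolerates the larger group at the level of 4-methoxyphenyl. No supporting evidence bears on this result.

On these data alone, whether the second ring or the ring nitrogen matters more stays open; naphthalen-2-yl and pyridin-2-yl on the carbonyl carbon would separate the two. As far as these compounds go, whether an aryl group is needed here at all also stays open, and a cyclohexyl group would address that.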